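The source may hold more compounds than are shown below. What is called first, only, known or untested is meant among the compounds shown, and "the series" means these compounds.

Series notes. Compound 1 `O=C(O)c1cn(Cc2ccc(-c3ccccc3)cc2)c2cc(N3CC4CNCC4C3)c(F)cc2c1=O` is measured in an assay on isolated protein for inhibition of DNA topoisomerase 1 (Homo sapiens), with a stated time of 15 min (on this read-out lower numbers stand for stronger inhibition and higher numbers for weaker inhibition), at 33300 nM. Two further compounds share the fluoro-substituted fused core with different attachments: compound 2 `NC[C@@H]1CCN(c2cc3c(cc2F)c(=O)n(N)c(=O)n3Cc2ccc(-c3ccccc3)cc2)C1` gives 25900 nM in this assay, and compound 3 `NC[C@@H]1CCN(c2cc3c(cc2F)c(=O)c(C(=O)O)cn3Cc2cc(-c3ccccc3)no2)C1` gives 58300 nM. The number for compound 1 lies among those of compounds 2 and 3, and each of those differs from it only within the usual scatter, so no ranking among the three is supported.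

Compound 4 `CNC[C@@H]1CCN(c2cc3c(cc2F)c(=O)c(C(=O)O)cn3Cc2ccc(-c3ccccc3)cc2)C1` is not yet measured. Relative to compound 1 the change is a group of 8 heavy atoms (6 carbon, 2 nitrogen; one five-membered non-aromatic ring with 1 hetero atom) in place of a group of 8 heavy atoms (6 carbon, 2 nitrogen; 2 five-membered non-aromatic rings with 1 hetero atom each), on an aromatic carbon. Among the measured compounds shown here, with no measured pair showing such a change, the step is expected to be a 1.0-fold lower number from compound 1 to compound 4 (0.02 log units; within the scatter), that is, none beyond the scatter. Compound 4 is therefore estimated at 32000 nM, with a range from 12000 nM to 80000 nM.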

Compound 4, half-maximal inhibitory concentration: 168000 nM
Compound 4: the middle estimate sits 5.3-fold (0.72 log units) below what was measured; measured number outside the range, above it.
By their numbers in this assay, from the lowest: compounds 2, 1 and 3 (each within the scatter of the next, the first and the last beyond it); then compound 4.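

In this assay, the aromatic carbon para to a fused ring proves sensitive to which group sits there: with 3-((methylamino)methyl)pyrrolidin-1-yl entering, the series shows a 5.0-fold higher number from compound 1 to compound 4 (0.70 log units; beyond the scatter), its first step between compounds differing in one place. The two groups match in their counts of heavy atoms, donors and acceptors, yet the numbers do not stay together. Nothing measured here accounts for this step. The methyl on the side-chain amine and the loss of the second ring remain unseparated. As far as these compounds go, how a piperazin-1-yl group would behave at this position also remains open.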